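A few compounds are considered here, and "the series" means these few. Any claim that something is new, unique, unknown or untested is made for them only; others in the source may bear on it.

Measured so far in a functional assay on HSC-2 cells (Homo sapiens) for cytotoxicity; a lower number here means that less compound is tolerated, a higher number that more compound is tolerated:
- compound 1, `COc1ccc(/C=C2\Cc3ccccc3/C(=C\c3ccc([N+](=O)[O-])cc3)C2=O)cc1`: 11000 nM
- compound 2, `COc1ccc(/C=C2\CCC/C(=C\c3ccc([N+](=O)[O-])cc3)C2=O)cc1OC`: 2300 nM
- compound 3, `COc1ccc(/C=C2\Cc3ccccc3/C(=C\c3ccc([N+](=O)[O-])cc3)C2=O)cc1OC`: 920 nM

Compound 1 and compound 3 share one core; compound 2 carries a different core, and how the two cores differ is not broken down here. Within the shared core, compound 3 differs from compound 1 by methoxy in place of hydrogen on an aromatic carbon and that step gave a 12-fold lower number from compound 1 to compound 3 (1.08 log units; beyond the scatter) in this assay. Compound 2 stands with its value between compound 1 and compound 3, beyond the scatter from each.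

Compound 4, `COc1cc(/C=C2\CCC/C(=C\c3ccc([N+](=O)[O-])cc3)C2=O)cc(OC)c1OC`, is not yet measured. Within the data shown here, it differs from compound 2 by methoxy in place of hydrogen on an aromatic carbon and is the same kind of change as the one from compound 1 to compound 3; the place is not the same word for word, since in compound 4 the entering group is also meta to a methoxy group.

For compound 4 a step in the same direction is expected, a 2.6-fold lower number from compound 2 to compound 4 (0.41 log units; beyond the scatter), because compound 3 showed a 12-fold lower number from compound 1 to compound 3 (1.08 log units; beyond the scatter), though a smaller one is taken, the surroundings of the place not being identical. Compound 4 is thus estimated at 900 nM in this assay, between 250 nM and 3000 nM.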

Compound 4, half-maximal cytotoxic concentration: 760 nM
For compound 4 the middle estimate is 1.2-fold (0.07 log units) above the measured one; the range from low to high includes it.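

In this assay, methoxy in place of hydrogen on an aromatic carbon again lowers the number, giving a 3.0-fold lower number from compound 2 to compound 4 (0.48 log units; beyond the scatter). Among these compounds, the direction of the step therefore holds on both cores, but its size does not carry over unchanged: the same change on two cores in this assay, a 12-fold lower number (1.08 log units; beyond the scatter) from compound 1 to compound 3 and a 3.0-fold lower number (0.48 log units; beyond the scatter) from compound 2 to compound 4, 4.0-fold (0.60 log units) apart, beyond the scatter of two such steps This rests on only two pairs, and the place of the change also differs, with the entering methoxy in compound 4 being ortho to one methoxy group and meta to another, so the data do not show how much of the gap belongs to the core and how much to the surroundings of the place.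

Still open, going by these compounds, is whether a third methoxy group on the core of compound 3, matching the arrangement in compound 4, would separate those two contributions. Also open, on these data alone, is whether a hydroxy group or an amine at the same place would shift the number in the same direction as methoxy.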